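The source may hold more compounds than are shown below. What is called first, only, known or untested is meant among the compounds shown, and "the series" means these compounds.

Measured so far:
- compound 1 `CN(C)c1ccc(C2C(C#N)=C(N)OC(c3c[nH]c4ccccc34)=C2C#N)cc1`: 26.7%
- compound 2 `Cc1ccccc1C1C(C#N)=C(N)OC(c2c[nH]c3ccccc23)=C1C#N`: 25.7%

In a functional assay, tested at 400 ug/mL (on this read-out higher numbers stand for a stronger effect at the one concentration tested and lower numbers for a weaker effect), compound 1 gives 26.7% and compound 2 gives 25.7%. Compound 2 is the lowest of the two numbers, with compound 1 nearest at a number 1 percentage points lower from compound 1 to compound 2 (within the scatter). Compound 3 `COc1ccc(C2C(C#N)=C(N)OC(c3c[nH]c4ccccc34)=C2C#N)cc1` is not yet measured; it differs from compound 2 by 4-methoxyphenyl in place of 2-methylphenyl on a saturated ring carbon. Among the measured compounds shown here, the only step on record, an aryl swap on the same saturated ring carbon, a number 1 percentage points lower from compound 1 to compound 2 (within the scatter), stayed within the scatter, and the measured aryl groups span no wider range. The step of a number 1.3 percentage points higher from compound 2 to compound 3 (within the scatter) is therefore expected to be small, with no direction beyond the scatter. Compound 3 is estimated at 27%, range 15% to 40%.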

Compound 3, a percentage reported as activity, at one concentration (the size of the read-out at that concentration, not a potency): 28.7%
Compound 3: the middle estimate sits 1.7 percentage points below what was measured; the measured number falls inside the stated range.
By their numbers in this assay, from the lowest: compounds 2, 1 and 3 (each within the scatter of the next).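

In this assay the swap to 4-methoxyphenyl on the saturated ring carbon stays flat (a number 3 percentage points higher from compound 2 to compound 3 (within the scatter)), and methoxy in place of dimethylamino on an aromatic carbon does too (a number 2 percentage points higher from compound 1 to compound 3 (within the scatter)). All three aryl groups at this position now read alike, including a change confined to the group on the aromatic carbon. No evidence bears on this flat reading. Open, from the compounds shown here alone, is whether a carboxylic acid or a primary amine on the phenyl ring would give a step beyond the scatter. Also open, going by these compounds, is whether a longer alkyl chain in place of the aryl group would do so.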